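The source may report more compounds than this note shows. Statements on the series, on what has been measured and on what is new or still open speak of the compounds shown alone.

Of the compounds shown here, two on one shared core have been measured in a functional assay (aorta) with Rattus norvegicus as the target; a higher number here means that more compound is needed for the effect, a lower number that less compound is needed. Compound 1 `N#Cc1ccc2c(c1)[C@@H](N1CCCC1=O)[C@H](O)C(CF)(CF)O2` gives 85.1 nM, while compound 2 `O=C1CCCN1[C@@H]1c2cc([N+](=O)[O-])ccc2OC(CF)(CF)[C@H]1O` gives 24 nM, the lower of the two numbers. Compound 3 `O=C1CCCN1[C@@H]1c2cc(C(F)(F)C(F)(F)F)ccc2OC(CF)(CF)[C@H]1O` has 1,1,2,2,2-pentafluoroethyl in place of nitro on an aromatic carbon, (1,1,2,2,2-pentafluoroethyl in place of nitro on an aromatic carbon). Among the compounds with values here, only one measured step bears on this change: nitro in place of cyano on an aromatic carbon, a 3.5-fold lower number from compound 1 to compound 2 (0.55 log units; beyond the scatter). This modest step lies beyond the scatter and shows that exchanging a group there can move the number. However, no compound with 1,1,2,2,2-pentafluoroethyl has been measured, so the data do not settle the direction. Within the data shown here, with only that single step from compound 1 as a guide, a change of similar or smaller size is expected in this assay, with a slight lean towards a higher number, as compound 2 at 24 nM is the lower of only two values. The estimated change is a 1.5-fold higher number from compound 2 to compound 3 (0.16 log units; within the scatter). For compound 3 the expected value is 35 nM, with an estimated range from 10 nM to 120 nM.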

Compound 3, half-maximal effective concentration: 6.31 nM
Compound 3: the middle estimate sits 5.5-fold (0.74 log units) above what was measured; measured number below the stated range.
By their numbers in this assay, from the lowest: compound 3; then compound 2; then compound 1.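

In this assay, the aromatic carbon that had already moved the number once moves it again in the same direction, with a 3.8-fold lower number from compound 2 to compound 3 (0.58 log units; beyond the scatter), so a group other than nitro can give a lower number here and nitro does not mark the low end of this position. Across the three groups on the shared core the span widens to a 13-fold lower number from compound 1 to compound 3 (1.13 log units; beyond the scatter), which is a large step where the earlier pair showed only a modest one. The lowest number so far belongs to 1,1,2,2,2-pentafluoroethyl, which brings more heavy atoms than nitro and none of its hydrogen-bond acceptors, so a low number at this position does not depend on a group with such acceptors, though nothing shown explains why the number falls.

With only three groups at this one position, the compounds shown cannot separate the contribution of the chain length of 1,1,2,2,2-pentafluoroethyl from that of its fluorine atoms. From the compounds shown here alone, it remains open how trifluoromethyl, a longer fluorinated chain or an amine on this aromatic carbon would read, and whether the number would keep falling or turn back up.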